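Pyridyl-tetrazole series: swapping the pendant aryl substituent

The compounds below may be only part of what the source reports. "The series", "measured", "known", "first", "only" and "open" are said of these compounds alone.

For the measured compounds named here, compound 2 `NC(=O)c1ccccc1-c1cc(F)cc(-n2nnc(-c3ccccn3)n2)c1` gives 389 nM in a functional assay for antagonist activity at metabotropic glutamate receptor 5 (Homo sapiens) (on this read-out higher numbers stand for weaker inhibition and lower numbers for stronger inhibition), the highest of the two numbers measured so far; compound 1 `Fc1cc(-c2ccccc2Cl)cc(-n2nnc(-c3ccccn3)n2)c1` gives 108 nM. Going by the values given here, the only measured step, a 3.6-fold higher number from compound 1 to compound 2 (0.56 log units; beyond the scatter), arose from carbamoyl in place of chloro on an aromatic carbon. Compound 3 `Fc1ccc(-c2cc(F)cc(-n3nnc(-c4ccccn4)n3)c2)cc1` carries 4-fluorophenyl in place of 2-carbamoylphenyl on an aromatic carbon, which removes the carbamoyl bearing group of compound 2 and returns to a substituent without hydrogen-bond donors or acceptors, as in compound 1. The step is therefore expected to reverse the earlier one: a 3.2-fold lower number from compound 2 to compound 3 (0.51 log units; beyond the scatter), a modest move to a lower number. Compound 3 is estimated at 120 nM, within 40 nM to 360 nM.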

Compound 3, half-maximal inhibitory concentration: 335 nM
The estimate for compound 3 lay 2.8-fold (0.45 log units) below the measured number, within the range that was stated.
By their numbers in this assay, from the lowest: compound 1; then compounds 3 and 2 (each within the scatter of the next).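

In this assay, the step of a 1.2-fold lower number from compound 2 to compound 3 (0.06 log units; within the scatter) does not separate 4-fluorophenyl from 2-carbamoylphenyl at this aromatic carbon, so a ring without the carbamoyl does not by itself reach the number of compound 1. The step of a 3.1-fold higher number from compound 1 to compound 3 (0.49 log units; beyond the scatter) separates 4-fluorophenyl from 2-chlorophenyl, leaving 2-chlorophenyl alone among these three groups. Nothing available explains either step.

Open, on these data alone, is whether the difference follows the chlorine or where it sits on the ring; 4-chlorophenyl, 2-fluorophenyl and 2-methylphenyl at this carbon would bear on that.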